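Removing the chloro group from compound 2

A few compounds are considered here, and "the series" means these few. Any claim that something is new, unique, unknown or untested is made for them only; others in the source may bear on it.

Measured in a functional assay on MCF7 cells (Homo sapiens) for antiproliferative activity, read by MTT assay, with a stated time of 72 h; on this read-out lower numbers stand for stronger inhibition and higher numbers for weaker inhibition:
- Compound 1 `O=C(Nc1ccc(Nc2nccc(NC3CCCCC3)n2)cc1)Nc1ccc(Cl)c(C(F)(F)F)c1`: 10800 nM
- Compound 2 `O=C(Nc1ccc(Nc2nccc(NC3CCCC3)n2)cc1)Nc1ccc(Cl)c(C(F)(F)F)c1`: 2330 nM
- Compound 3 `O=C(Nc1ccc(Nc2nccc(Nc3ccccc3Cl)n2)cc1)Nc1ccc(Cl)c(C(F)(F)F)c1`: 27900 nM

Of these three, compound 2 gives the lowest number, 2330 nM, so it is the most potent in this assay. Compound 4 `O=C(Nc1ccc(Nc2nccc(NC3CCCC3)n2)cc1)Nc1cccc(C(F)(F)F)c1` differs from it in one place: hydrogen in place of chloro on an aromatic carbon. This turns 4-chloro-3-(trifluoromethyl)phenyl into 3-(trifluoromethyl)phenyl.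

Among the measured compounds shown here, no measured step touches this place. All three replace the group on a nitrogen on an aromatic ring instead: a 4.6-fold lower number from compound 1 to compound 2 (0.67 log units; beyond the scatter), a 2.6-fold higher number from compound 1 to compound 3 (0.41 log units; beyond the scatter) and a 12-fold higher number from compound 2 to compound 3 (1.08 log units; beyond the scatter). They show that numbers in this small set can move, but they say nothing direct about the chloro group. The direction is therefore uncertain, and only a small shift toward a higher number in this assay is expected, perhaps none beyond the scatter. The expected change is a 1.7-fold higher number from compound 2 to compound 4 (0.23 log units; within the scatter). Compound 4 is estimated at 4000 nM, with an expected range from 1300 nM to 12000 nM.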

Compound 4, half-maximal inhibitory concentration: 5180 nM
For compound 4 the middle estimate is 1.3-fold (0.11 log units) below the measured one; the range from low to high includes it.
By their numbers in this assay, from the lowest: compound 2; then compound 4; then compound 1; then compound 3.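

In this assay, among the compounds shown here, the removal of the chloro group is a 2.2-fold higher number from compound 2 to compound 4 (0.35 log units; beyond the scatter) and shows that this position on the aromatic ring, which no earlier step touched, can change the read-out. In this one pair, the compound that keeps the chloro group inhibits more strongly, so hydrogen does not fully replace it. Nothing shown here explains the shift.

From the compounds shown here alone, this is a single pair with cyclopentyl on the nitrogen, so it remains open whether removing chloro would have a similar effect with cyclohexyl or 2-chlorophenyl there. The compounds shown also leave open how fluoro, methyl, methoxy or a nitrile on the same aromatic carbon would compare with chloro and hydrogen, and what would happen if the trifluoromethyl group were replaced.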